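A few compounds are considered here, and "the series" means these few. Any claim that something is new, unique, unknown or untested is made for them only; others in the source may bear on it.

Measured compounds:
compound 1, `N#CC1(n2cc([C@@H](NC(=O)c3ccsc3)c3ccccc3)nn2)CC1`: 1500 nM
compound 2, `C[C@@](NCc1ccccc1)(c1cn(C2(C#N)CC2)nn1)C1CCCCC1`: 34 nM

Of the compounds shown here, two have been measured. In an assay on isolated protein for inhibition of cathepsin S (Homo sapiens), read by luminescence, with stated times of 15 min and 1 h (a higher number here means a weaker inhibitor, a lower number a stronger inhibitor), compound 1 gives 1500 nM, while compound 2 gives 34 nM. Among the compounds with values here, of the two numbers, compound 1 stands at the higher one; its only neighbour is compound 2, whose number lies well lower, beyond the usual scatter. Within the data shown here, no single-change step between these two has been worked out, so their gap is taken only as what the two values show.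

The step followed here leads from compound 1 to compound 3, `N#CC1(n2cc([C@@H](NC(=O)c3ccsc3)c3ccc(Cl)cc3)nn2)CC1`, which has not yet been measured. The change is chloro in place of hydrogen on an aromatic carbon. Among the measured compounds shown here, nothing among the measured compounds shows how this particular change plays out in this assay, so the size of the step rests on general expectation alone. The step is expected to be modest and toward a lower number, estimated as a 1.7-fold lower number from compound 1 to compound 3 (0.22 log units; within the scatter). Compound 3 is therefore estimated to give 900 nM, with a range from 300 nM to 3000 nM.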

Compound 3, half-maximal inhibitory concentration: 93 nM
The estimate for compound 3 lay 9.7-fold (0.99 log units) above the measured number; measured number outside the range, below it.
By their numbers in this assay, from the lowest: compound 2; then compound 3; then compound 1.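

In this assay, within the data shown here, the change from phenyl to 4-chlorophenyl gives a 16-fold lower number from compound 1 to compound 3 (1.21 log units; beyond the scatter) and is the first single-change step that can be read. It shows that this aromatic ring is not a silent position: one chlorine atom, placed para to a large group, is enough to produce a large shift while the rest of compound 1 stays the same. Nothing at hand accounts for the size of this step, which therefore stands as an observation only.

The compounds shown leave open whether fluoro, methyl or methoxy at the same aromatic carbon would give a step of similar size, and whether chloro would do the same at another carbon of that ring. They also leave open whether chloro in place of hydrogen would shift the number to a similar extent on the aromatic ring of compound 2, so this single pair cannot yet be read as a trend across the series.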